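The compounds below may be only part of what the source reports. "The series", "measured", "known", "first", "only" and "open" are said of these compounds alone.

In a functional assay on MCF7 cells (Homo sapiens) for inhibition, read by CCK-8 assay, with a stated time of 72 h (a higher number here means a weaker inhibitor, a lower number a stronger inhibitor), compound 1 `Cc1cccc(NS(=O)(=O)c2cccc(CCCCCCNC(=O)/C=C/c3cccnc3)c2)c1` reads 4 nM and compound 2 `Cc1ccc(C)c(NS(=O)(=O)c2cccc(CCCCCCNC(=O)/C=C/c3cccnc3)c2)c1` reads 0.6 nM, while compound 3 `CCc1ccc(NS(=O)(=O)c2cccc(CCCCCCNC(=O)/C=C/c3cccnc3)c2)cc1` reads 3.64 nM in the same test. Compound 3 stands level with compound 1 (a 1.1-fold lower number from compound 1 to compound 3 (0.04 log units; within the scatter)). Compound 2 is the strongest of the three (a 6.1-fold higher number from compound 2 to compound 3 (0.78 log units; beyond the scatter)).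

The move to compound 4 `O=C(/C=C/c1cccnc1)NCCCCCCc1cccc(S(=O)(=O)Nc2ccc(F)cc2)c1` is fluoro in place of ethyl on an aromatic carbon, para to a large group (fluoro in place of ethyl on an aromatic carbon). Among the compounds with values here, no measured compound carries fluoro, so no step tests this change directly. The nearest evidence is the exchange of aryl groups on the sulfonamide nitrogen between compound 1 and compound 3, which stayed within the scatter. Within the data shown here, the one large step on a simple substituent came with an added methyl (a 6.7-fold lower number from compound 1 to compound 2 (0.82 log units; beyond the scatter)), and compound 4 has no counterpart to that methyl. In this assay the expected result is no step beyond the scatter, an estimated small change (a 1.2-fold higher number from compound 3 to compound 4 (0.09 log units; within the scatter)). Compound 4 is therefore expected at 4.5 nM (1.5 nM to 13 nM).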

Compound 4, half-maximal inhibitory concentration: 0.91 nM
Compound 4: middle estimate off by 4.9-fold (0.69 log units), on the high side; the measured number lies below the stated range.
By their numbers in this assay, from the lowest: compounds 2 and 4 (each within the scatter of the next); then compounds 3 and 1 (each within the scatter of the next).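

In this assay, replacing 4-ethylphenyl with 4-fluorophenyl on the sulfonamide nitrogen gives a step beyond the scatter (a 4.0-fold lower number from compound 3 to compound 4 (0.60 log units; beyond the scatter)), so this position responds to a change of substituent without any added methyl. The earlier exchange between 3-methylphenyl and 4-ethylphenyl stayed within the scatter, whereas 4-fluorophenyl separates from 3-methylphenyl (a 4.4-fold lower number from compound 1 to compound 4 (0.64 log units; beyond the scatter)) and stands level with 2,5-dimethylphenyl (a 1.5-fold higher number from compound 2 to compound 4 (0.18 log units; within the scatter)), so two differently substituted aryl groups now share the low end of the series. No measurement shown accounts for these steps.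

On these data alone, whether the gain depends on fluoro itself or only on the loss of ethyl remains open, and 4-chlorophenyl, 4-methoxyphenyl or unsubstituted phenyl on the sulfonamide nitrogen would help separate the two. Also open, as far as these compounds go, is whether fluoro adds to a second substituent, as in 2,5-difluorophenyl.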